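Swapping the Nitrooxyphenyl Arm for a Hydroxynaphthyl

The source may hold more compounds than are shown below. What is called first, only, known or untested is meant among the compounds shown, and "the series" means these compounds.

Three analogues sharing one core have been measured. Compound 1 `CN(C)CCn1cnnc1-c1cc(Oc2ccc(NC(=O)N/N=C/c3c[nH]c4ccccc34)cc2F)ccn1` gives 1300 nM in a functional assay on HT-29 cells (Homo sapiens) for cytotoxicity, read by MTT assay, with a stated time of 72 h; on this read-out higher numbers stand for weaker inhibition and lower numbers for stronger inhibition. Compound 2 `CN(C)CCn1cnnc1-c1cc(Oc2ccc(NC(=O)N/N=C/c3cc(C(C)(C)C)cc(C(C)(C)C)c3O)cc2F)ccn1` gives 680 nM in this assay. Compound 3 `CN(C)CCn1cnnc1-c1cc(Oc2ccc(NC(=O)N/N=C/c3ccccc3O[N+](=O)[O-])cc2F)ccn1` gives 950 nM in this assay. The number of compound 3 lies between those of compound 1 and compound 2, and both gaps are within the scatter, so the three compounds cannot be ranked against one another.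

Among the measured compounds shown here, only one single-point step is available: a 1.4-fold lower number from compound 1 to compound 3 (0.14 log units; within the scatter). It shows that exchanging the aryl group on the carbon double-bonded to nitrogen left the read-out essentially unchanged.

Compound 4 `CN(C)CCn1cnnc1-c1cc(Oc2ccc(NC(=O)N/N=C/c3c(O)ccc4ccccc34)cc2F)ccn1` differs from compound 3 in that (2-hydroxynaphthalen-1-yl in place of 2-(nitrooxy)phenyl on a carbon with a double bond to nitrogen). For the measured compounds named here, no measured step covers a hydroxynaphthalenyl group at this position, and the one aryl exchange on record, from compound 1 to compound 3, stayed within the scatter, while compound 2, which also carries a hydroxyl on its aryl group, gives a number close to that of compound 3. The expected step is therefore small, a 1.1-fold lower number from compound 3 to compound 4 (0.05 log units; within the scatter), in no reliable direction. Compound 4 is accordingly estimated at 850 nM in this assay, with a range from 350 nM to 2100 nM.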

Compound 4, half-maximal inhibitory concentration: 670 nM
Beside the measured number, compound 4's estimate is 1.3-fold (0.10 log units) above it; the measured number falls inside the stated range.
By their numbers in this assay, from the lowest: compounds 4, 2, 3 and 1 (each within the scatter of the next).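

In this assay, 2-hydroxynaphthalen-1-yl in place of 2-(nitrooxy)phenyl on a carbon with a double bond to nitrogen gives a 1.4-fold lower number from compound 3 to compound 4 (0.15 log units; within the scatter), and the same group in place of 1H-indol-3-yl gives a 1.9-fold lower number from compound 1 to compound 4 (0.29 log units; within the scatter). The earlier compounds shown here had not covered a group with 2 six-membered aromatic rings of carbon only at this position, and this larger aromatic group also leaves the read-out within the scatter, so the four compounds still show no aryl exchange here that separates one compound from another. No data on hand give a reason for this flat result.

Every group shown at this position is aromatic, so it remains open whether a saturated group such as cyclohexyl, or an aryl group carrying an amine or a carboxylic acid, would move the number beyond the scatter. On these data alone, the role of the hydroxyl also remains open, as a plain naphthalen-1-yl group would be needed to separate it from the second ring.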